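This account rests on a few compounds, and the source may have more. Where it says the series, first, only, none or still open, it means among the compounds named here.

Measured compounds:
compound 1, `CCC(CC)Nc1nc(OC)c(-c2ccc(Cl)cc2Cl)nc1OC`, 0.0417 h
compound 2, `CCc1nc(-c2ccc(Cl)cc2Cl)c(CC)nc1SC(C)CC`, 0.0683 h
compound 3, `CCC(CC)Nc1nc(C)c(-c2ccc(Cl)cc2Cl)nc1C`, 0.0533 h

All three were examined in an in vitro ADME assay on microsomes (Rattus norvegicus) for metabolic stability; a lower number here means that the compound disappears faster, a higher number that the compound lasts longer. Each gives a very short half-life, meaning each disappears quickly when exposed to microsomes. Compound 2 nominally has the top number of the three, but compound 3 and compound 1 both lie within the usual scatter of it, so the three cannot really be told apart on these numbers. Going by the values given here, no pair among them differs in only one place, so no single structural step can be read off.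

Compound 4, `CCc1nc(-c2ccc(Cl)cc2Cl)c(CC)nc1NC(C1CC1)C1CC1`, has not yet been measured in this assay. It differs from compound 2 in one place: (dicyclopropylmethyl)amino in place of (sec-butyl)sulfanyl on an aromatic carbon. Compounds 1 and 3 also carry an amino group on the shared core and give numbers close to compound 2, so no step beyond the scatter is expected here in either direction. The step from compound 2 to compound 4 is estimated as a 1.1-fold lower number from compound 2 to compound 4 (0.06 log units; within the scatter). Compound 4 is therefore expected to give 0.06 h, between 0.025 h and 0.15 h.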

Compound 4, half-life: 0.0417 h
The estimate for compound 4 lay 1.4-fold (0.16 log units) above the measured number; the measured number falls inside the stated range.
By their numbers in this assay, from the lowest: compounds 1, 4, 3 and 2 (each within the scatter of the next).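

In this assay, going by these compounds alone, putting (dicyclopropylmethyl)amino in place of (sec-butyl)sulfanyl on this aromatic carbon gives a 1.6-fold lower number from compound 2 to compound 4 (0.21 log units; within the scatter), the first step that can be read at a single position. This exchange of an open sulfur-linked chain for a nitrogen-linked group with two three-membered rings and a hydrogen-bond donor therefore yields two compounds that cannot be told apart on these numbers, and both half-lives remain short. Nothing available here explains why the two compounds lie so close.

As far as these compounds go, it remains open whether any group at this position can shift the half-life beyond the usual scatter. A morpholine ring or a carboxylic acid on the same carbon, with both ethyl groups kept, would show whether this position responds to a more different substituent.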